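A few compounds are considered here, and "the series" means these few. Any claim that something is new, unique, unknown or untested is made for them only; others in the source may bear on it.

Measured compounds:
compound 1 `CCN(Cc1cccc(C)c1)c1cc(C)nc2c(-c3cnc(N(C)C)cc3C)c(C)nn12`: 2.4 nM
compound 2 `CCN(Cc1ccccc1F)c1cc(C)nc2c(-c3cnc(N(C)C)cc3C)c(C)nn12`: 3.4 nM

In an assay on CHO cells for binding affinity to corticotropin-releasing factor receptor 1 (Homo sapiens) (a higher number here means a weaker inhibitor, a lower number a stronger inhibitor), compound 2 gives the higher of the two numbers, though the gap between the two is only a 1.4-fold higher number from compound 1 to compound 2 (0.15 log units; within the scatter), which is within the scatter. Compound 3 `CCN(Cc1ccc(Cl)cc1)c1cc(C)nc2c(-c3cnc(N(C)C)cc3C)c(C)nn12` is the next compound in the series and differs from compound 2 by 4-chlorophenyl in place of 2-fluorophenyl on a saturated chain carbon bound to a nitrogen on an aromatic ring. Within the data shown here, the only step that bears on this exchange is the one from compound 1 to compound 2, where swapping one substituted phenyl for another on the same saturated chain carbon gave a 1.4-fold higher number from compound 1 to compound 2 (0.15 log units; within the scatter), a change no larger than the scatter. On that basis a further swap of the same kind is expected to move this assay little, and the step from compound 2 to compound 3 is estimated at a 1.2-fold higher number from compound 2 to compound 3 (0.07 log units; within the scatter), with no direction beyond the scatter. Compound 3 is therefore expected to give 4 nM in this assay, with a likely range from 1.5 nM to 12 nM.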

Compound 3, inhibition constant: 1.3 nM
Compound 3: the middle estimate sits 3.1-fold (0.49 log units) above what was measured, and the stated range ends above it.
By their numbers in this assay, from the lowest: compounds 3, 1 and 2 (each within the scatter of the next, the first and the last beyond it).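

Among these compounds, at this position, on a saturated chain carbon bound to a nitrogen on an aromatic ring, the exchange of 2-fluorophenyl for 4-chlorophenyl gives the first step in this assay that passes the scatter (a 2.6-fold lower number from compound 2 to compound 3 (0.42 log units; beyond the scatter)), so the choice of substituted phenyl can register here, if modestly. The exchange of 3-methylphenyl for 4-chlorophenyl stays inside the scatter (a 1.8-fold lower number from compound 1 to compound 3 (0.27 log units; within the scatter)), so only compound 2 and compound 3 stand apart in this series. Nothing available accounts for that separation.

The step changes both the halogen and its place on the ring, so the compounds shown cannot separate the two, and 4-fluorophenyl would help to read them apart. As far as these compounds go, whether a phenyl bearing an amine or a carboxylic acid is tolerated here also stays open.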